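Swapping the cyanopyridine ether in compound 1

A few compounds are considered here, and "the series" means these few. Any claim that something is new, unique, unknown or untested is made for them only; others in the source may bear on it.

Compound 1 `CC(CCNC(=O)c1c(Cl)cncc1Cl)N1CCC(C(Oc2cccc(C#N)n2)c2ccc(C(F)(F)F)cc2)CC1`: 15700 nM
Compound 2 `CC(CCNC(=O)c1c(Cl)cncc1Cl)N1CCC(C(Oc2ccccn2)c2ccc(Br)cc2)CC1`: 33700 nM
Compound 3 `CCO/N=C(/c1ccc(Br)cc1)C1CCN(C(C)CCNC(=O)c2c(C)cc[n+]([O-])c2C)CC1`: > 177000 nM

In an ADME assay on PBMC cells (Homo sapiens) for cytotoxicity (a lower number here means that less compound is tolerated, a higher number that more compound is tolerated), compound 1 gives 15700 nM, the lowest of the numbers available. The closest number belongs to compound 2 at 33700 nM, and the gap between the two lies beyond the usual scatter. Compound 3 is reported only as a limit, > 177000 nM, so it gives no number to rank against the others.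

The account now turns to compound 4 `CC(CCNC(=O)c1c(Cl)cncc1Cl)N1CCC(C(Oc2cccc(Cl)c2)c2ccc(C(F)(F)F)cc2)CC1`, which has not yet been measured. It carries 3-chlorophenyl in place of 6-cyanopyridin-2-yl on an oxygen on a saturated carbon. Among the measured compounds shown here, no pair of measured compounds differs by this change alone, so the data offer no direct precedent for its size. For the measured compounds named here, the only firm anchor is compound 1 at 15700 nM. In this assay, a small step toward a lower number is expected, of a size not clearly beyond the scatter. The expected change is a 1.8-fold lower number from compound 1 to compound 4 (0.27 log units; within the scatter). Compound 4 is expected at 8500 nM, with an estimated range from 3500 nM to 20000 nM.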

Compound 4, half-maximal cytotoxic concentration: 8100 nM
Estimate against measurement, compound 4: 1.0-fold (0.02 log units) above; low and high end bracket the measured number.
By their numbers in this assay, from the lowest: compounds 4 and 1 (each within the scatter of the next); then compound 2. At a limit, above all of these: compound 3.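

In this assay, among the compounds shown here, putting 3-chlorophenyl in place of 6-cyanopyridin-2-yl on an oxygen on a saturated carbon gives a 1.9-fold lower number from compound 1 to compound 4 (0.29 log units; within the scatter), the first step that can be read at this position. The two groups have little in common beyond a six-membered aromatic ring: the change removes the nitrile, the ring nitrogen and both hydrogen-bond acceptors and brings in a chlorine, yet the two compounds cannot be told apart in this read-out. At this position, then, and on the core of compound 1, this exchange leaves no difference that stands clear of the scatter, although a single step cannot show that other groups would behave the same way. Nothing measured in this set bears on why the two compounds read alike.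

From the compounds shown here alone, the nitrile, the ring nitrogen and the chlorine all differ in this one step, so what each contributes alone remains open, and a 3-cyanophenyl group on the same oxygen would begin to separate them. Going by these compounds, it is also open how a group of a different kind at this position, such as an amine or a carboxylic acid, would read in this assay.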